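The source may hold more compounds than are shown below. What is called first, only, known or untested is meant among the compounds shown, and "the series" means these compounds.

Three compounds have been measured so far in a functional assay on U2OS cells for antagonist activity at proto-oncogene Wnt-3 (Homo sapiens), read by a luciferase reporter, with a stated time of 18 h; a lower number here means that less compound is needed, a higher number that more compound is needed for the effect:

Compound 1 `O=C(CN1CCNCC1)N1CCC(NS(=O)(=O)c2cc(S(=O)(=O)c3ccccc3)ccc2C(F)(F)F)CC1`: 250 nM
Compound 2 `CC(C)(C)C(=O)N1CCC[C@H]1C(=O)N1CCC(NS(=O)(=O)c2cc(S(=O)(=O)c3ccccc3)ccc2C(F)(F)F)CC1`: 270 nM
Compound 3 `CC(C)(C)CC(=O)N1CCC[C@H]1C(=O)N1CCC(NS(=O)(=O)c2cc(S(=O)(=O)c3ccccc3)ccc2C(F)(F)F)CC1`: 120 nM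

Compound 2 gives the highest number of the three, but its separation from compound 1, a 1.1-fold higher number from compound 1 to compound 2 (0.03 log units; within the scatter), lies within the scatter, so the two cannot be ordered; compound 3 sits clearly below it, as a 2.3-fold lower number from compound 2 to compound 3 (0.35 log units; beyond the scatter) shows, and below compound 1, as a 2.1-fold lower number from compound 1 to compound 3 (0.32 log units; beyond the scatter) shows.

Compound 4 `CN1CCC[C@H]1C(=O)N1CCC(NS(=O)(=O)c2cc(S(=O)(=O)c3ccccc3)ccc2C(F)(F)F)CC1` differs from compound 2 in one place: methyl in place of (tert-butyl)carbonyl on an amine nitrogen in a ring. Going by the values given here, no measured step removes the acyl group at this position; the only step at the same carbonyl, a 2.3-fold lower number from compound 2 to compound 3 (0.35 log units; beyond the scatter), enlarges it by one carbon and brings a modest gain. Compound 1 shows that a basic amine in the side chain is compatible with a number close to that of compound 2. The data therefore give no firm direction for a loss of the whole acyl group.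

Compound 4 is expected to give about 350 nM, within a range from 130 nM to 950 nM. The expected step, a 1.3-fold higher number from compound 2 to compound 4 (0.11 log units; within the scatter), is small and likely within the scatter, with the risk tilted toward a higher number.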

Compound 4, half-maximal effective concentration: 230 nM
Compound 4: middle estimate off by 1.5-fold (0.18 log units), on the high side; the range from low to high includes it.
By their numbers in this assay, from the lowest: compounds 3, 4, 1 and 2 (each within the scatter of the next, the first and the last beyond it).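

In this assay, the acyl group on the amine nitrogen of the five-membered ring proves dispensable: methyl in place of (tert-butyl)carbonyl, with 6 heavy atoms leaving and 1 entering, gives a 1.2-fold lower number from compound 2 to compound 4 (0.07 log units; within the scatter). Methyl in place of neopentylcarbonyl gives a 1.9-fold higher number from compound 3 to compound 4 (0.28 log units; within the scatter), and 1-methylpyrrolidin-2-yl in place of (piperazin-1-yl)methyl gives a 1.1-fold lower number from compound 1 to compound 4 (0.04 log units; within the scatter), so all three steps stay within the scatter and this position accepts groups of very different size without a readable change. No measurement available here accounts for this tolerance.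

The compounds shown leave open whether a free amine, with hydrogen on this ring nitrogen, or a longer chain such as propyl would behave like methyl. They also leave open how a carboxylic acid on the same nitrogen's substituent would read.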